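The source may report more compounds than this note shows. Statements on the series, on what has been measured and on what is new or still open speak of the compounds shown alone.

In an assay on cell membranes (strain Wistar) for displacement of a labelled ligand from 5-hydroxytryptamine receptor 7 (Rattus norvegicus) (a lower number here means a stronger inhibitor, a higher number a weaker inhibitor), compound 1 `CCOc1nc2c(c(=O)n(C)c(=O)n2C)n1CCCN1CCN(c2ccccc2OC)CC1` gives 410 nM, and compound 2 `CCCOc1nc2c(c(=O)n(C)c(=O)n2C)n1CCCN1CCN(c2ccccc2OC)CC1` gives 328 nM. The change between them, (methyl in place of hydrogen on a saturated chain carbon, two bonds along the chain from an oxygen on an aromatic ring), made the step of a 1.3-fold lower number from compound 1 to compound 2 (0.10 log units; within the scatter). Compound 3 `CCOc1nc2c(c(=O)n(C)c(=O)n2C)n1CCCCN1CCc2ccccc2C1` gives 83 nM in this assay, the strongest binding of the three measured compounds; how its core differs from that of compound 1 is not broken down here.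

Compound 4 `CCCOc1nc2c(c(=O)n(C)c(=O)n2C)n1CCCCN1CCc2ccccc2C1` carries the same change relative to compound 3: methyl in place of hydrogen on a saturated chain carbon, two bonds along the chain from an oxygen on an aromatic ring, at the same place as in the earlier pair. Since that earlier step was within the scatter, compound 4 is expected to sit close to compound 3, with an estimated step of a 1.2-fold lower number from compound 3 to compound 4 (0.07 log units; within the scatter) in this assay. Compound 4 is therefore estimated at 70 nM, most likely between 35 nM and 140 nM.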

Compound 4, inhibition constant: 57 nM
For compound 4 the middle estimate is 1.2-fold (0.09 log units) above the measured one; measured number inside the range.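

On the core of compound 3, the change from ethoxy to propoxy gave a step within the scatter in this assay: a 1.5-fold lower number from compound 3 to compound 4 (0.16 log units; within the scatter). Set beside the earlier pair, the change carried over from one core to the other without a detectable difference: the same change on two cores in this assay, a 1.3-fold lower number (0.10 log units; within the scatter) from compound 1 to compound 2 and a 1.5-fold lower number (0.16 log units; within the scatter) from compound 3 to compound 4, 1.2-fold (0.07 log units) apart, within the scatter of two such steps

This shows only that the added methyl made no difference beyond the scatter on these two cores; it does not show that the same would hold on any other core, and two pairs with such small steps cannot establish a real shift in either direction. The compounds shown leave open what a methoxy or a butoxy group in this place would give. They also leave open whether a longer chain would still stay within the scatter on both cores.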